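Ketone to Anilide on a Triazole Thioether Series

This account rests on a few compounds, and the source may have more. Where it says the series, first, only, none or still open, it means among the compounds named here.

Measured so far:
- compound 1 `COc1cc(-c2nnc(SCC(=O)c3ccccc3)n2N)cc(OC)c1OC`: 53000 nM
- compound 2 `COc1cc(-c2nnc(SCC(=O)c3ccc(C(F)(F)F)cc3)n2N)cc(OC)c1OC`: 16700 nM

Going by the values given here, in a functional assay on HCT-116 cells (Homo sapiens) for antiproliferative activity, read by MTT assay, with a stated time of 48 h (on this read-out lower numbers stand for stronger inhibition and higher numbers for weaker inhibition), compound 1 gives 53000 nM, the highest of the two numbers measured; its only neighbour is compound 2, which differs by a trifluoromethyl in place of hydrogen on an aromatic carbon and gives a 3.2-fold lower number from compound 1 to compound 2 (0.50 log units; beyond the scatter), a modest step beyond the scatter.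

Compound 3 `COc1cccc(NC(=O)CSc2nnc(-c3cc(OC)c(OC)c(OC)c3)n2N)c1` is not yet measured. It differs from compound 1 in one place: (3-methoxyphenyl)amino in place of phenyl on a carbonyl carbon. Among the compounds with values here, the single measured step, from compound 1 to compound 2, alters a different part of the molecule and so offers no direct guide to this change; the data hold no pair in which a phenyl ketone becomes an anilide. The expectation for compound 3 is therefore broad and centred near compound 1, with a step of a 1.5-fold lower number from compound 1 to compound 3 (0.18 log units; within the scatter) not clearly beyond the scatter. Compound 3 is estimated at 35000 nM, expected between 9000 nM and 120000 nM.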

Compound 3, half-maximal inhibitory concentration: 680 nM
Beside the measured number, compound 3's estimate is 51-fold (1.71 log units) above it; measured number below the stated range.
By their numbers in this assay, from the lowest: compound 3; then compound 2; then compound 1.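

In this assay the swap of phenyl for (3-methoxyphenyl)amino on the carbonyl carbon gives a 78-fold lower number from compound 1 to compound 3 (1.89 log units; beyond the scatter) and so shows that this position can move the number far more than the trifluoromethyl change did, which gave a 3.2-fold lower number from compound 1 to compound 2 (0.50 log units; beyond the scatter) on the ketone series. The same swap made against the 4-(trifluoromethyl)phenyl group still gives a 25-fold lower number from compound 2 to compound 3 (1.39 log units; beyond the scatter) so the gain holds against the stronger of the two ketones as well. Nothing available here explains why this change has so large an effect.

From the compounds shown here alone, the swap changes the linking atom and adds a methoxy group in one move, so the share of each remains unknown, and a plain phenylamino group would be needed to separate them. Going by these compounds, whether a benzylamino or cyclohexylamino group on the same carbonyl carbon would keep this gain also stays open.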